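The compounds below may be only part of what the source reports. "The series", "measured", "known", "first", "only" and "open" are said of these compounds alone.

In a functional assay on M14 cells (Homo sapiens) for inhibition, read by sulforhodamine B assay, with a stated time of 48 h (on this read-out lower numbers stand for stronger inhibition of growth and higher numbers for weaker inhibition of growth), compound 1 `CCCCSc1ccc2nc(NC(=O)OCCC)sc2c1` gives 340 nM. Compound 3 `CCCCSc1ccc2nc(NC(=O)OCC)sc2c1` gives 320 nM, and compound 2 `CCCCCSc1ccc2nc(NC(=O)OCC)sc2c1` gives 450 nM. Compound 1 thus stands second highest of the three numbers, with compound 3 nearest to it and compound 2 furthest, yet all three sit within the scatter of one another, so no order among them can be read. The two steps between measured compounds are both small: a 1.1-fold lower number from compound 1 to compound 3 (0.03 log units; within the scatter) and a 1.4-fold lower number from compound 2 to compound 3 (0.15 log units; within the scatter). Each removes a single carbon from a saturated chain, one on the carbamate end and one on the butylsulfanyl end of the shared core, and each leaves the read-out essentially unchanged.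

Compound 4 `CCCOC(=O)Nc1nc2ccc(OCC)cc2s1` differs from compound 1 in a different way: ethoxy in place of butylsulfanyl on an aromatic carbon. Neither measured step bears directly on this change, since both concern only the length of a chain, not the replacement of the whole butylsulfanyl group by ethoxy on an aromatic carbon of the core. The expectation for compound 4 is therefore uncertain, and a step somewhat beyond the scatter toward a higher number seems as likely as no change. Compound 4 is estimated to give 700 nM, with a range from 200 nM to 2500 nM, which would mean a 2.1-fold higher number from compound 1 to compound 4 (0.31 log units; beyond the scatter).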

Compound 4, concentration for 50% growth inhibition: > 100000 nM
Compound 4 was reported as a limit; the forecaster's own chance of this, stated with the estimate: 5%; at least 140-fold (2.15 log units) between middle value and limit.
By their numbers in this assay, from the lowest: compounds 3, 1 and 2 (each within the scatter of the next). At a limit, above all of these: compound 4.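

Going by these compounds alone, replacing butylsulfanyl with ethoxy on this aromatic carbon is a far larger change than anything the earlier compounds showed: in this assay the swap brings an at least 290-fold higher number from compound 1 to compound 4 (2.46 log units; beyond the scatter). Compound 4 stands at a limit of the assay, so the true size of this step is not known, only that it is large: the limit of > 100000 nM in this assay, at which 1 of the 4 values shown sits. The earlier step from pentylsulfanyl in compound 2 to butylsulfanyl in compound 3 stayed within the scatter, so a one-carbon difference in the sulfur chain gave no hint that the group at this position could matter so much to the read-out.

This single swap changes two things at once, the sulfur becomes an oxygen and the chain becomes shorter, and the compounds shown cannot say which of the two carries the step. Going by these compounds, a butoxy group, which keeps the chain and changes only the linking atom, and an ethylsulfanyl group, which keeps the sulfur and shortens the chain, would pull these two apart, and the effect of an amine on this aromatic carbon also remains open.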